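The source may report more compounds than this note shows. Statements on the series, on what has been measured and on what is new or still open speak of the compounds shown alone.

Compound 3 `COc1ccc2nc(C)cc(OCC(=O)Nc3ccc(Br)cc3)c2c1` stands among three compounds in an ADME assay on HepG2 cells (Homo sapiens) for cytotoxicity, read by trypan blue exclusion, with a stated time of 48 h, in the presence of a further agent that is not named here (a lower number here means that less compound is tolerated, a higher number that more compound is tolerated), whose results are all limits rather than numbers. In this assay compound 3 gives > 125000 nM, a limit of the assay. Compound 1 `COc1ccc2nc(C)cc(OCC(=O)Nc3ccccc3)c2c1` gives > 155000 nM in this assay, likewise a limit. Compound 2 `COc1ccccc1NC(=O)COc1cc(C)nc2ccc(C(F)(F)F)cc12` gives > 128000 nM in this assay, again a limit. Among the compounds with values here, the only step between compounds that differ in one place, a step that the two limits leave unreadable from compound 1 to compound 3, is left unreadable by the two limits, so the bromo in place of hydrogen on an aromatic carbon cannot be weighed. Compound 4 `COc1ccc2nc(C)cc(OCC(=O)Nc3ccc(C)cc3)c2c1` has not been measured in this assay. It differs from compound 3 by methyl in place of bromo on an aromatic carbon, a methyl in place of bromo on an aromatic carbon, para to a large group. Within the data shown here, no measured step bears on this change directly; the three limits (the limit of > 125000 nM in this assay, at which 1 of the 3 values shown sits), the limit of > 128000 nM in this assay, at which 1 of the 3 values shown sits, and the limit of > 155000 nM in this assay, at which 1 of the 3 values shown sits, are all that is known. The step that the limit leaves unreadable from compound 3 to compound 4 is therefore expected to be none beyond the scatter, and compound 4 is expected to remain at a limit as well. Compound 4 is estimated at 150000 nM in this assay, within 60000 nM to 400000 nM, most likely reported only as a limit.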

Compound 4, half-maximal cytotoxic concentration: > 149000 nM
Compound 4: only a limit was reported; the forecaster's own chance of this, stated with the estimate: 85%; the middle value is on the limit's open side.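

In this assay compound 4 gives > 149000 nM, a limit of the assay. Within the data shown here, neither the change from compound 3 to compound 4 nor the one from compound 1 to compound 4 can be read. The compounds shown leave open at what concentration any of them becomes cytotoxic, and whether bromo, methyl or hydrogen at this place makes any difference.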